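The source may report more compounds than this note shows. Statements on the series, on what has been measured and on what is new or still open speak of the compounds shown alone.

In a functional assay on A549 cells (Homo sapiens) for cytotoxicity, read by MTT assay, with a stated time of 72 h (a higher number here means a weaker inhibitor, a lower number a stronger inhibitor), the measured compounds are:

Compound 1 `CNC(=O)c1cc(Oc2ccc(NC(=O)c3nn(-c4ccc(Br)cc4F)c(=O)cc3C)cc2F)ccn1` gives 7930 nM.
Compound 2 `CNC(=O)c1cc(Oc2ccc(NC(=O)c3nn(-c4ccccc4OC(F)(F)F)c(=O)cc3C)cc2F)ccn1` gives > 40000 nM, a limit only.
Compound 3 `CNC(=O)c1cc(Oc2ccc(NC(=O)c3nn(-c4ccccc4F)c(=O)cc3C)cc2F)ccn1` gives > 40000 nM, a limit only.

Going by the values given here, compound 1 holds the only true number; the other two sit at the limit of > 40000 nM in this assay, at which 2 of the 3 values shown sit. Compound 4 `Cc1cc(=O)n(-c2ccc(Br)cc2F)nc1C(=O)Nc1ccc(Oc2ncnc3ccsc23)c(F)c1` differs from compound 1 at a different place: a group of 9 heavy atoms (6 carbon, 2 nitrogen, 1 sulfur; one five-membered aromatic ring with 1 hetero atom, one six-membered aromatic ring with 2 hetero atoms) in place of a group of 10 heavy atoms (7 carbon, 2 nitrogen, 1 oxygen; one six-membered aromatic ring with 1 hetero atom), on an oxygen on an aromatic ring. The measured steps, an at least 5.0-fold higher number from compound 1 to compound 2 (0.70 log units; beyond the scatter) and an at least 5.0-fold higher number from compound 1 to compound 3 (0.70 log units; beyond the scatter), all alter the aryl on the aromatic nitrogen and leave the group on the oxygen untouched, so none of them bears on this change. With no guide, the step is expected to stay within the scatter, with a 1.1-fold lower number from compound 1 to compound 4 (0.05 log units; within the scatter). Compound 4 is therefore estimated at 7000 nM, between 1500 nM and 30000 nM.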

Compound 4, half-maximal inhibitory concentration: 2980 nM
Compound 4: the middle estimate sits 2.3-fold (0.37 log units) above what was measured; low and high end bracket the measured number.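

Swapping 2-(methylcarbamoyl)pyridin-4-yl for the two-ring group on the oxygen gives a 2.7-fold lower number from compound 1 to compound 4 (0.43 log units; beyond the scatter) in this assay. Going by these compounds alone, this shows that the group on the oxygen, untouched by the earlier steps, also moves the number, and that the 4-bromo-2-fluorophenyl series keeps a measurable value without the methylcarbamoyl group. Nothing shown explains why this change has this effect.

From the compounds shown here alone, it remains open whether the new group would have the same effect alongside the other aryl groups on the aromatic nitrogen. Going by these compounds, how an amine or a carboxylic acid attached to the new group would shift the number also remains open.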